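A few compounds are considered here, and "the series" means these few. Any claim that something is new, unique, unknown or untested is made for them only; others in the source may bear on it.

Among the compounds with values here, in a functional assay on cells (Cancer cell lines, Homo sapiens) for cytotoxicity, with a stated time of 48 h (a lower number here means a stronger inhibitor of growth, a higher number a weaker inhibitor of growth), compound 1 (`COc1ccc(CN2C(=O)/C(=C\c3cc(OC)c(OC)c(OC)c3)c3ccccc32)cc1`) gives 26300 nM, the higher of the two numbers measured so far. Compound 2 (`COc1cc(/C=C2/C(=O)N(C)c3ccc(O)cc32)cc(OC)c1OC`) gives 6300 nM, a lower number by a margin beyond the scatter. Compound 3 (`COc1cc(/C=C2\C(=O)N(Cc3ccc(Cl)cc3)c3ccccc32)cc(OC)c1OC`) differs from compound 1 in one place, with 4-chlorobenzyl in place of 4-methoxybenzyl, that is, chloro in place of methoxy on an aromatic carbon, para to a large group: chloro in place of methoxy on an aromatic carbon. Within the data shown here, no measured pair shows this change, so only a modest shift in this assay is expected. The expected step is a 1.6-fold lower number from compound 1 to compound 3 (0.22 log units; within the scatter), toward a lower number and possibly within the scatter. Compound 3 is expected at 16000 nM, with an estimated range of 5000 nM to 50000 nM.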

Compound 3, concentration for total growth inhibition: 7600 nM
Beside the measured number, compound 3's estimate is 2.1-fold (0.32 log units) above it, within the range that was stated.
By their numbers in this assay, from the lowest: compounds 2 and 3 (each within the scatter of the next); then compound 1.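

In this assay, chloro in place of methoxy on an aromatic carbon, para to a large group, gives a 3.5-fold lower number from compound 1 to compound 3 (0.54 log units; beyond the scatter). Within the data shown here, this is the first sign that this position responds to a single change, which compound 1 and compound 2 could not show, since they differ in more than one place. Nothing measured here accounts for the step. On these data alone, whether the step belongs to chloro itself or to the loss of methoxy stays open. So does what an amine or a carboxylic acid at this position would give.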